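A few compounds are considered here, and "the series" means these few. Any claim that something is new, unique, unknown or untested is made for them only; others in the source may bear on it.

Among the measured compounds shown here, compound 2 `CC(C)(C)OC(=O)NCCCC(=O)Oc1cc(-c2oc3cc(O)cc(O)c3c(=O)c2O)ccc1O` gives 0.000208 h in a physicochemical assay for pharmacokinetics (on this read-out higher numbers stand for a longer-lived compound and lower numbers for a shorter-lived compound), the higher of the two numbers so far; compound 1 `C[C@@H](NC(=O)OC(C)(C)C)C(=O)Oc1cc(-c2oc3cc(O)cc(O)c3c(=O)c2O)ccc1O` gives 0.0000297 h. For the measured compounds named here, the only measured step, a 7.0-fold higher number from compound 1 to compound 2 (0.85 log units; beyond the scatter), joins these two. Compound 3 `CC(C)(C)OC(=O)NCCCCCC(=O)Oc1cc(-c2oc3cc(O)cc(O)c3c(=O)c2O)ccc1O` differs from compound 2 by 2-((tert-butoxycarbonyl)amino)ethyl in place of (tert-butoxycarbonyl)amino on a saturated chain carbon, three bonds along the chain from a carbonyl carbon. That change is not the same as the step from compound 1, which also altered branching, so it bears on it only loosely. A small rise or none beyond the scatter is expected, a 1.9-fold higher number from compound 2 to compound 3 (0.28 log units; within the scatter), and compound 3 is estimated at 0.0004 h, between 0.0001 h and 0.0015 h.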

Compound 3, half-life: 0.000367 h
Compound 3: middle estimate off by 1.1-fold (0.04 log units), on the high side, within the range that was stated.
By their numbers in this assay, from the lowest: compound 1; then compounds 2 and 3 (each within the scatter of the next).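

In this assay, the step of a 1.8-fold higher number from compound 2 to compound 3 (0.25 log units; within the scatter) shows that 2-((tert-butoxycarbonyl)amino)ethyl in place of (tert-butoxycarbonyl)amino at this position, on a saturated chain carbon, three bonds along the chain from a carbonyl carbon, leaves the two compounds within the scatter of each other. Compound 2 and compound 3 therefore cannot be told apart on this read-out. Nothing available here accounts for this result.

As far as these compounds go, it remains open whether a longer chain would separate from compound 3, and what a free amine or a carboxylic acid at the chain end would give.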